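Compound 3 and the Step to a Trimethoxyphenyl Group

A few compounds are considered here, and "the series" means these few. Any claim that something is new, unique, unknown or untested is made for them only; others in the source may bear on it.

Among the measured compounds shown here, in a functional assay on THP-1 cells (Homo sapiens) for inhibition, read by sulforhodamine B assay, with a stated time of 48 h, tested at 50 uM (a lower number here means less inhibition of growth, a higher number more inhibition of growth at the concentration tested), three compounds have numbers so far. Compound 1 (`COc1cc(/C=C/C(=O)/C=C/c2cccs2)ccc1OCc1cn(CCCCCOc2cc(=O)oc3ccccc23)nn1`) stands at 34% and compound 2 (`COc1cc(/C=C/C(=O)/C=C/c2cc(OC)c(OC)c(OC)c2)ccc1OCc1cn(CCOc2cc(=O)oc3ccccc23)nn1`) at 99% while compound 3 (`COc1cccc(/C=C/C(=O)/C=C/c2ccc(OCc3cn(CCCOc4cc(=O)oc5ccccc45)nn3)c(OC)c2)c1`) lies at 58% as the second highest of the three. Its gaps to compound 1 and to compound 2 both lie beyond the scatter.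

The step to compound 4 (`COc1cc(/C=C/C(=O)/C=C/c2cc(OC)c(OC)c(OC)c2)ccc1OCc1cn(CCCOc2cc(=O)oc3ccccc23)nn1`) is a single change, counted as 3,4,5-trimethoxyphenyl in place of 3-methoxyphenyl on a double-bonded chain carbon bound to a double-bonded chain carbon and placing 3,4,5-trimethoxyphenyl in place of 3-methoxyphenyl on a double-bonded chain carbon bound to a double-bonded chain carbon. For the measured compounds named here, no two measured compounds differ in only one place, so this step has no direct precedent. Going by the values given here, the only hint is compound 2, which also carries the 3,4,5-trimethoxyphenyl group and stands at 99% as the highest number so far. One compound is thin support, and the expected range stays wide for that reason. A rise beyond the scatter is nevertheless expected in this assay with a number 24 percentage points higher from compound 3 to compound 4 (beyond the scatter) as the estimated step. For compound 4 the estimated value is 82% within an expected range from 60% to 100% of growth inhibition.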

Compound 4, percent growth inhibition at one concentration: 79%
For compound 4 the middle estimate is 3 percentage points above the measured one, and the stated range covers the measured number.
By their numbers in this assay, from the lowest: compound 1; then compound 3; then compound 4; then compound 2.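

With a number 21 percentage points higher from compound 3 to compound 4 (beyond the scatter) in this assay, the place on a double-bonded chain carbon bound to a double-bonded chain carbon now has its first direct reading. Among the compounds shown here, because the rest of the molecule stays the same, this pair shows that exchanging 3-methoxyphenyl for 3,4,5-trimethoxyphenyl at this place is enough on its own to shift growth inhibition beyond the scatter, which the earlier compounds, all differing in more than one place, could not show. The entering group has more oxygen atoms and more hydrogen-bond acceptors than the group it replaces, but no measurement here links either count to the rise in growth inhibition.

As far as these compounds go, it remains open whether all three methoxy groups are needed, or whether a 3,4-dimethoxyphenyl group, a 4-hydroxyphenyl group or a phenyl ring carrying a dimethylamino group would serve as well at this place. Also open, from the compounds shown here alone, is whether the same exchange gives a similar step with a longer or shorter chain on the other side of the molecule, as compound 1 and compound 2 each differ from compound 3 in more than one place.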